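A few compounds are considered here, and "the series" means these few. Any claim that something is new, unique, unknown or untested is made for them only; others in the source may bear on it.

Of the compounds shown here, three sharing one core have been tested in a functional assay on ZR-75-1 cells (Homo sapiens) for cytotoxicity, read by MTT assay, with a stated time of 72 h; on this read-out higher numbers stand for an effect only at larger amounts of compound and lower numbers for an effect already at smaller amounts. Compound 1 `CCc1cccc2c(OC)c(-c3occ(C)c3C(=O)OC)ccc12`, which carries methoxycarbonyl, gives 1.3 ug/mL. Compound 3 `CCc1cccc2c(OC)c(-c3occ(C)c3CBr)ccc12`, which carries bromomethyl at that place, gives 4.6 ug/mL, the higher of the two actual numbers. Compound 2 `CCc1cccc2c(OC)c(-c3occ(C)c3C(=O)NC)ccc12`, which carries methylcarbamoyl, gives only a limit, > 10 ug/mL.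

Compound 4 `CCc1cccc2c(OC)c(-c3occ(C)c3COC(=O)CCN(CC)CC)ccc12` differs from compound 3 in one place: ((2-(diethylamino)ethyl)carbonyl)oxy in place of bromo on a saturated chain carbon bound to an aromatic carbon. Among the measured compounds shown here, no measured step makes this exchange, so the nearest guidance comes from the three steps among the tested compounds, all of which alter the same substituent. They are an at least 7.6-fold higher number from compound 1 to compound 2 (0.88 log units; beyond the scatter), a 3.5-fold higher number from compound 1 to compound 3 (0.55 log units; beyond the scatter) and an at least 2.1-fold lower number from compound 2 to compound 3 (0.33 log units; beyond the scatter). All three are modest in size, but they set no common direction. Starting from compound 3, the number falls towards compound 1 and rises towards compound 2, so neither a gain nor a loss can be expected with confidence. The new group is also much larger than the bromo it replaces, which widens the uncertainty. The expected outcome is therefore a 1.0-fold lower number from compound 3 to compound 4 (0.01 log units; within the scatter), with no clear shift anticipated in this assay. For compound 4 the estimated value is 4.5 ug/mL, with an expected range of 1.3 ug/mL to 15 ug/mL.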

Compound 4, concentration for half-maximal effect: 1.7 ug/mL
For compound 4 the middle estimate is 2.6-fold (0.42 log units) above the measured one; the measured number falls inside the stated range.
By their numbers in this assay, from the lowest: compounds 1 and 4 (each within the scatter of the next); then compound 3. At a limit, above all of these: compound 2.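

The step of a 2.7-fold lower number from compound 3 to compound 4 (0.43 log units; beyond the scatter) shows that the saturated chain carbon bound to an aromatic carbon accepts far more than the bromo: ((2-(diethylamino)ethyl)carbonyl)oxy, with 10 heavy atoms against 1, does not raise the number in this assay but lowers it. The earlier compounds shown here varied this substituent only among small groups, so they could not show that a long chain ending in diethylamino is compatible with an effect at small amounts of compound. With this exchange, compound 1 at 1.3 ug/mL and compound 4 at 1.7 ug/mL lie within the scatter of each other, so an ester on this chain carbon reaches the same range as the methoxycarbonyl group set directly on the aromatic carbon.

The compounds shown do not separate the ester link from the diethylamino group, which a plain acetyloxy group or a diethylamino group set directly on the chain carbon would do, and a longer or shorter chain before the amine also stays unexplored. Among the compounds shown here, compound 2 gives only a limit in this assay, and it stays the one compound here without an actual number: the limit of > 10 ug/mL in this assay, at which 1 of the 4 values shown sits.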